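A few compounds are considered here, and "the series" means these few. Any claim that something is new, unique, unknown or untested is made for them only; others in the source may bear on it.

Series notes, antagonism of the neuronal receptor.

Of the compounds shown here, two have been measured in an in vitro functional assay on HEK ts201 cells for antagonist activity at Neuronal acetylcholine receptor; alpha4/beta2 (Homo sapiens), read by fluorescence and calcium flux; on this read-out higher numbers stand for weaker inhibition and lower numbers for stronger inhibition. Compound 1, `O=C(OCc1ccccc1-c1ccccc1)C1CCCN(CCCc2ccccc2)C1`, is an ester of a branched piperidine core, and in this assay compound 1 gives 17800 nM. Compound 2, `O=C(OCC1CCCN(CCCc2ccccc2)C1)c1ccccc1N1C(=O)CC(Cc2ccc(Cl)cc2)C1=O`, carries a succinimide-bearing benzoate ester instead, and in this assay compound 2 gives 10700 nM. Going by the values given here, the two numbers are within the scatter of each other, so compound 2 and compound 1 cannot be told apart on these data; compound 2 simply stands with the one other number measured.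

Compound 3, `O=C(OCC1CCCN(CCCc2ccccc2)C1)c1ccccc1N1C(=O)CC(CCc2ccccc2)C1=O`, is next. It differs from compound 2 in one place: benzyl in place of 4-chlorophenyl on a saturated chain carbon bound to a saturated ring carbon. Among the compounds with values here, no step between measured compounds shows what such a change does, so nothing beyond the scatter is expected in this assay in either direction; the step from compound 2 to compound 3 that the estimate implies is a 1.1-fold lower number from compound 2 to compound 3 (0.03 log units; within the scatter). For compound 3 the expected value in this assay is 10000 nM, with a range from 4000 nM to 25000 nM.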

Compound 3, half-maximal inhibitory concentration: 5130 nM
The estimate for compound 3 lay 1.9-fold (0.29 log units) above the measured number; the range from low to high includes it.
By their numbers in this assay, from the lowest: compound 3; then compounds 2 and 1 (each within the scatter of the next).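

In this assay this position responds to a change, with a 2.1-fold lower number from compound 2 to compound 3 (0.32 log units; beyond the scatter) as a modest step and the first one in the series that lies beyond the scatter. The swap keeps the heavy-atom count, the single six-membered aromatic ring of carbon only and the absence of hydrogen-bond donors and acceptors in the group, yet it makes two changes at once: the chlorine leaves and, read one bond further out, 4-chlorobenzyl becomes phenethyl, so the step can be assigned only to the pair of changes and not to either one alone. No measurement on these compounds bears on why the number moved.

Going by these compounds, whether the chlorine or the length of the chain carries the step stays open, and an unsubstituted benzyl or a 4-chlorophenethyl group at this position would separate the two. Also open, on these data alone, is whether a longer chain such as 3-phenylpropyl would continue the step, and whether a ring-bearing chain here tolerates an amine or a carboxylic acid at its end.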